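This account rests on a few compounds, and the source may have more. Where it says the series, first, only, none or still open, it means among the compounds named here.

Measured so far:
Compound 1, `Cc1noc(C)c1S(=O)(=O)N1CCC(N2CCC(C)CC2)CC1`: > 5000 nM
Compound 2, `CC1CCCN(C2CCN(S(=O)(=O)c3ccc(OC(F)F)cc3)CC2)C1`: 105 nM
Compound 3, `Cc1cc(C)c(S(=O)(=O)N2CCC(C(=O)N3CCC(C)CC3)CC2)c(C)c1`: > 5000 nM

All three were tested in a functional assay on DLD-1 cells (Homo sapiens) for antiproliferative activity, read by CellTiter-Glo, with a stated time of 72 h; a lower number here means a stronger inhibitor, a higher number a weaker inhibitor. For compound 1 the result is only a limit of the assay, > 5000 nM, so no number is known for it. Compound 1 thus stands at the limit of > 5000 nM in this assay, at which 2 of the 3 values shown sit. For compound 3 the result is likewise only a limit, > 5000 nM. Among the measured compounds shown here, compound 2 is the one compound of the three with a measured number, giving 105 nM in this assay.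

Compound 4, `Cc1cccc(S(=O)(=O)N2CCC(N3CCC(C)CC3)CC2)c1`, has not yet been measured. It differs from compound 1 in one place: 3-methylphenyl in place of 3,5-dimethyl-1,2-oxazol-4-yl on a sulfonyl sulfur. The rest of the shared core, with its sulfonamide nitrogen in a ring and the methylpiperidine attached to it, is kept unchanged.

For the measured compounds named here, no step between two measured compounds is available to guide the size of this change. Compound 2, which also carries a six-membered aromatic ring of carbon only on its sulfonyl sulfur and a similar core, gives 105 nM, and this is the nearest point of reference. On that basis compound 4 is expected to move from a limit to a measurable number, a step of an at least 16-fold lower number from compound 1 to compound 4 (1.22 log units; beyond the scatter), though with wide uncertainty. The estimate for compound 4 is 300 nM, within a range from 60 nM to 3000 nM.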

Compound 4, half-maximal inhibitory concentration: 25 nM
Estimate against measurement, compound 4: 12-fold (1.08 log units) above, outside the stated range (below it).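

In this assay, putting 3-methylphenyl in place of 3,5-dimethyl-1,2-oxazol-4-yl on the sulfonyl sulfur gives an at least 200-fold lower number from compound 1 to compound 4 (2.30 log units; beyond the scatter) and thereby shows, for the first time among these compounds, that this one position can decide on its own between a compound with a measurable number and one at the limit of the assay. The two groups have the same count of heavy atoms, and the visible difference lies in the ring: one five-membered aromatic ring with 2 hetero atoms leaves, and one six-membered aromatic ring of carbon only enters. The step is a bound rather than an exact size, since the result for compound 1 is only a limit: the limit of > 5000 nM in this assay, at which 2 of the 4 values shown sit.

The compounds shown leave open whether the methyl group of the 3-methylphenyl contributes to this gain or whether the carbon-only ring is enough, a question that a plain phenyl or a chlorine in place of the methyl could address. As far as these compounds go, it also remains open whether a pyridine ring on the sulfonyl sulfur, a six-membered aromatic ring containing a nitrogen, would behave like 3-methylphenyl or like 3,5-dimethyl-1,2-oxazol-4-yl.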